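A few compounds are considered here, and "the series" means these few. Any claim that something is new, unique, unknown or untested is made for them only; others in the source may bear on it.

In a functional assay on HL-60 cells (Homo sapiens) for cytotoxicity, read by WST assay, with a stated time of 48 h (on this read-out higher numbers stand for an effect only at larger amounts of compound and lower numbers for an effect already at smaller amounts), compound 1 (`COc1cccc(C[C@H]2C(=O)OC[C@@H]2Cc2ccccc2)c1`) gives 66000 nM and compound 2 (`COCOc1cccc(C[C@H]2C(=O)OC[C@@H]2Cc2ccccc2)c1`) gives 80000 nM. Compound 2 therefore stands with compound 1, and the two numbers do not separate.

Compound 3 (`CCCCCCCOc1cccc(C[C@H]2C(=O)OC[C@@H]2Cc2ccccc2)c1`) remains unmeasured. It differs from compound 2 by hexyl in place of methoxy on a saturated chain carbon bound to an oxygen on an aromatic ring, with hexyl in place of methoxy on a saturated chain carbon bound to an oxygen on an aromatic ring. Cut one bond further out, the same difference reads methoxymethoxy to heptyloxy.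

Within the data shown here, only one measured step bears on this change: a 1.2-fold higher number from compound 1 to compound 2 (0.08 log units; within the scatter). It sits at the same place but involves a much smaller change, so it sets no size for the present one. The data hold no long chain at this place, and the direction is therefore a tentative judgement. A moderately lower number is expected in this assay, with no change beyond the scatter still possible. The expected step is a 3.2-fold lower number from compound 2 to compound 3 (0.51 log units; beyond the scatter). For compound 3 the estimated value is 25000 nM, with an expected range of 8000 nM to 80000 nM.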

Compound 3, half-maximal effective concentration: 81000 nM
Estimate against measurement, compound 3: 3.2-fold (0.51 log units) below, and the stated range ends below it.
By their numbers in this assay, from the lowest: compounds 1, 2 and 3 (each within the scatter of the next).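

In this assay, hexyl in place of methoxy on a saturated chain carbon bound to an oxygen on an aromatic ring gives a 1.0-fold higher number from compound 2 to compound 3 (0.01 log units; within the scatter), and hexyl in place of hydrogen at the same place gives a 1.2-fold higher number from compound 1 to compound 3 (0.09 log units; within the scatter). The earlier step covered only a small change, whereas the much larger exchange of methoxymethoxy for heptyloxy also leaves the numbers together, so across compounds 1, 2 and 3 the size of this chain does not separate the compounds in this assay. No measurement at hand speaks to why the numbers stay together.

Still open is whether any group at this place can move the number beyond the scatter, since an amine or a carboxylic acid carried on the chain would be a different kind of change from the plain ethers shown here. Also open, going by these compounds, is whether a free hydroxy group in place of the whole ether would stand with these three compounds or apart from them.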